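The source may hold more compounds than are shown below. What is called first, only, known or untested is meant among the compounds shown, and "the series" means these compounds.

Measured so far in a functional assay on ileum for inhibition of histamine H1 receptor (Cavia porcellus); a higher number here means a weaker inhibitor, a lower number a stronger inhibitor:
- compound 1, `CCOCCn1c(N2CCN(C)CC2)nc2ccccc21`: 10 nM
- compound 2, `CC(C)CCn1c(N2CCN(C)CC2)nc2ccccc21`: 1400 nM
- compound 3, `CCCOCCn1c(N2CCN(C)CC2)nc2ccccc21`: 20 nM

Compound 3 stands second highest of the three numbers. Its nearest neighbour is compound 1, which lies within the scatter of repeated measurements, so the two cannot be told apart; compound 2 lies far from both, with a 70-fold lower number from compound 2 to compound 3 (1.85 log units; beyond the scatter).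

The next compound is compound 4, `CCCn1c(N2CCN(C)CC2)nc2ccccc21`, which has not yet been measured in this assay. Going from compound 3 to compound 4 the change is methyl in place of propoxy on a saturated chain carbon, two bonds along the chain from an aromatic nitrogen. In plainer terms, the chain that carries the oxygen is cut back to a plain propyl chain, so the hydrogen-bond acceptor in the side chain is lost.

Going by the values given here, two measured steps bear on this. When the oxygen-bearing chain was replaced by an all-carbon chain, there was a 140-fold higher number from compound 1 to compound 2 (2.15 log units; beyond the scatter). When the all-carbon chain was replaced by an oxygen-bearing one, there was a 70-fold lower number from compound 2 to compound 3 (1.85 log units; beyond the scatter). Both steps point the same way: the oxygen in the chain goes with a much lower number, its absence with a much higher one. A large step upward is therefore expected for compound 4, of about a 50-fold higher number from compound 3 to compound 4 (1.70 log units; beyond the scatter). Compound 4 is estimated at 1000 nM, with a range from 200 nM to 5000 nM.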

Compound 4, half-maximal inhibitory concentration: 380 nM
The estimate for compound 4 lay 2.6-fold (0.42 log units) above the measured number; measured number inside the range.
By their numbers in this assay, from the lowest: compounds 1 and 3 (each within the scatter of the next); then compound 4; then compound 2.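

In this assay, trimming 2-propoxyethyl to propyl gives a large loss of potency (a 19-fold higher number from compound 3 to compound 4 (1.28 log units; beyond the scatter)), and the same kind of cut from the ethoxy-bearing chain gives a step of similar scale (a 38-fold higher number from compound 1 to compound 4 (1.58 log units; beyond the scatter)), so the propyl chain of compound 4 now stands as a direct reference for both oxygen-bearing chains. The new result also shows that the all-carbon chains do not share one level: methyl in place of isopropyl at this place, on a saturated chain carbon two bonds along the chain from an aromatic nitrogen, gives a modest gain (a 3.7-fold lower number from compound 2 to compound 4 (0.57 log units; beyond the scatter)), so the absence of the oxygen does not alone set the number, and the shape of the carbon chain counts as well. Nothing measured here gives a reason for either trend.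

Still open, from the compounds shown here alone, is whether an unbranched butyl chain would sit nearer compound 4 or compound 2, which would help separate the effect of branching from that of chain length. Also open, going by these compounds, is whether a hydroxyl or an amine in the place of the chain oxygen would keep the low numbers seen for compound 1 and compound 3.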